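This account rests on a few compounds, and the source may have more. Where it says the series, first, only, none or still open, it means among the compounds named here.

Of the compounds shown here, three sharing one core have been tested in a functional assay on MGC-803 cells (Homo sapiens) for cytotoxicity, read by MTT assay, with a stated time of 72 h; on this read-out higher numbers stand for weaker inhibition and lower numbers for stronger inhibition. Within the data shown here, compound 1 `O=C(NC(=S)NNc1ncnc2ccccc12)c1ccccc1F` gives 5010 nM, and compound 3 `O=C(NC(=S)NNc1ncnc2ccccc12)c1ccc(F)cc1` gives 3600 nM; the only single-point step among the measured compounds is a 1.4-fold lower number from compound 1 to compound 3 (0.14 log units; within the scatter), a 4-fluorophenyl in place of a 2-fluorophenyl on the carbonyl carbon. Compound 2 `COc1cc2ncnc(NNC(=S)NC(=O)c3ccccc3Cl)c2cc1OC` carries a (2-chlorophenyl)carbonyl group, and in this assay compound 2 gives 6440 nM, the highest of the three numbers, though its gaps to compound 1 and to compound 3 both fall within the scatter, so no order among the three can be read from them.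

Compound 4 `COc1cc2ncnc(NNC(=S)NC(=O)c3ccccc3C)c2cc1OC` differs from compound 2 in one place: methyl in place of chloro on an aromatic carbon. Among the measured compounds shown here, none of the measured steps concerns this kind of change; the single measured step, between compound 1 and compound 3, exchanges one fluorophenyl for another and stays within the scatter, so it gives no direction here. With nothing pointing up or down, the number for compound 4 is expected to stay close to that of compound 2, and the expected step is a 1.1-fold lower number from compound 2 to compound 4 (0.03 log units; within the scatter), no larger than the scatter. Compound 4 is therefore estimated at 6000 nM, with a range from 2500 nM to 14000 nM.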

Compound 4, half-maximal inhibitory concentration: 11100 nM
For compound 4 the middle estimate is 1.9-fold (0.27 log units) below the measured one; the range from low to high includes it.
By their numbers in this assay, from the lowest: compounds 3, 1, 2 and 4 (each within the scatter of the next, the first and the last beyond it).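

Going from 2-chlorophenyl to 2-methylphenyl, an exchange of one heavy atom for another on an aromatic carbon ortho to a large group, gives a 1.7-fold higher number from compound 2 to compound 4 (0.24 log units; within the scatter) in this assay for this pair. The earlier fluorophenyl step changed where one group sat, whereas this one exchanges the group itself, and at this place chloro and methyl cannot be told apart by the numbers in this assay. No measurement is at hand that would explain what these two groups do here.

On these data alone, it remains open whether a quite different group at this same place, such as an amine, a carboxylic acid or a nitrile, would produce a step beyond the scatter. As far as these compounds go, it is also open whether the exchange of chloro for methyl would read the same on the core of compound 1, which lacks the two methoxy groups that compound 2 and compound 4 share.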